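A few compounds are considered here, and "the series" means these few. Any claim that something is new, unique, unknown or untested is made for them only; others in the source may bear on it.

In an ADME assay on T29 cells (Homo sapiens) for cytotoxicity, read by sulforhodamine B assay, with a stated time of 3 days (a lower number here means a stronger inhibitor, a higher number a weaker inhibitor), compound 1 (`OCc1cn(Cc2ccc(Cl)cc2)c2ccccc12`) gives > 31600 nM, which is a limit and not a number. Compound 2 (`CC(=O)OCc1cn(Cc2ccc(Cl)cc2)c2ccccc12`) gives > 31600 nM, also a limit. Compound 3 (`Cc1cn(Cc2ccc(Cl)cc2)c2ccccc12`) gives > 31600 nM, again only a limit. The series therefore stands at the limit of > 31600 nM in this assay, at which 3 of the 3 values shown sit, and compound 3 has no number from which to count.

Compound 4 (`COC(=O)CNCc1cn(Cc2ccc(Cl)cc2)c2ccccc12`) carries ((methoxycarbonyl)methyl)amino in place of hydrogen on a saturated chain carbon bound to an aromatic carbon. Going by the values given here, three measured steps concern this same carbon: a step that the two limits leave unreadable from compound 1 to compound 3, a step that the two limits leave unreadable from compound 2 to compound 3 and a step that the two limits leave unreadable from compound 1 to compound 2. None has a readable size, and none brings in the entering group, so they give no measured size or direction to carry over. The working expectation is that compound 4 stays near the limit, resting on compound 3 at > 31600 nM. The expected step in this assay is an at least 1.0-fold lower number from compound 3 to compound 4 (0.02 log units; that floor lies within the scatter), an estimate with no firm direction. Compound 4 is estimated at 30000 nM, with an expected range of 10000 nM to 40000 nM.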

Compound 4, half-maximal inhibitory concentration: 31600 nM
Compound 4: the middle estimate sits 1.1-fold (0.02 log units) below what was measured; low and high end bracket the measured number.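

In this assay compound 4 gives 31600 nM, so ((methoxycarbonyl)methyl)amino on a saturated chain carbon bound to an aromatic carbon is the first change shown that yields a countable read-out. The read-out shows a number no higher from compound 3 to compound 4 (the limit leaves the size open), a number no higher from compound 2 to compound 4 (the limit leaves the size open) and a number no higher from compound 1 to compound 4 (the limit leaves the size open). Each of these steps starts from a limit and cannot be read in size, so no size can be given for this change. Most of the series still rests at one ceiling: the limit of > 31600 nM in this assay, at which 3 of the 4 values shown sit.

The compounds shown leave open whether any group on this carbon gives a clearly lower number than compound 4. Going by these compounds, how a carboxylic acid in place of the methyl ester, or a longer chain on the amine, reads in this assay also stays open.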